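The source may report more compounds than this note shows. Statements on the series, on what has been measured and on what is new or still open speak of the compounds shown alone.

In a functional assay on HCT-116 cells (Homo sapiens) for antiproliferative activity, read by MTT assay, with a stated time of 48 h (a higher number here means a weaker inhibitor, a lower number a stronger inhibitor), compound 1 (`C=C(CO)C(CCCCC)n1cnc2c(Cl)ncnc21`) returns only a limit, > 50000 nM. Compound 2 (`C=C(CO)C(CCCCCC)n1cnc2c(Cl)ncnc21`) gives 30200 nM. Compound 3 (`C=C(CO)C(CCCCCCC)n1cnc2c(Cl)ncnc21`) gives 22400 nM, which places it level with compound 2, as a 1.3-fold lower number from compound 2 to compound 3 (0.13 log units; within the scatter) shows. Compound 4 (`C=C(CO)C(c1ccccc1)n1cnc2c(Cl)ncnc21`) differs from compound 3 by phenyl in place of heptyl on a saturated chain carbon bound to an aromatic nitrogen and a double-bonded chain carbon. The nearest guides are chain-length steps, namely an at least 1.6-fold lower number from compound 1 to compound 2 (0.21 log units; that floor lies within the scatter) and the modest at least 2.2-fold lower number from compound 1 to compound 3 (0.34 log units; beyond the scatter). None of them exchanges a chain for a ring, so they guide only loosely. In this assay, a small move to a higher number is therefore expected, estimated as a 1.4-fold higher number from compound 3 to compound 4 (0.15 log units; within the scatter). Compound 4 is expected at 32000 nM, with an estimated range of 15000 nM to 50000 nM.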

Compound 4, half-maximal inhibitory concentration: 33300 nM
Estimate against measurement, compound 4: 1.0-fold (0.02 log units) below, within the range that was stated.
By their numbers in this assay, from the lowest: compounds 3, 2 and 4 (each within the scatter of the next). At a limit, above all of these: compound 1.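

In this assay, phenyl stands in for heptyl or hexyl on a saturated chain carbon bound to an aromatic nitrogen and a double-bonded chain carbon with no change beyond the scatter: a 1.5-fold higher number from compound 3 to compound 4 (0.17 log units; within the scatter) and a 1.1-fold higher number from compound 2 to compound 4 (0.04 log units; within the scatter). This position therefore carries an aromatic ring about as well as these chains, which the chain-only compounds could not show. Against pentyl the step reads an at least 1.5-fold lower number from compound 1 to compound 4 (0.17 log units; that floor lies within the scatter), only a floor, since compound 1 stands at a limit: the limit of > 50000 nM in this assay, at which 1 of the 4 values shown sits.

Going by these compounds, whether a benzyl group or a pyridine ring at this carbon would give a lower number remains open. So does the effect of a chain longer than heptyl.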